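This account rests on a few compounds, and the source may have more. Where it says the series, first, only, none or still open, it means among the compounds named here.

Measured so far in an ADME assay on HEL cells (Homo sapiens) for cytotoxicity, with a stated time of 3 days; on this read-out lower numbers stand for higher toxicity in this test and higher numbers for lower toxicity in this test:

Compound 1 `CCC1(Cc2ccccc2)OS(=O)(=O)C=C1OCCCCc1ccccc1`: >= 20000 nM
Compound 2 `CCC1(Cc2ccccc2)OS(=O)(=O)C=C1OCC#N`: > 400000 nM
Compound 3 `CCC1(Cc2ccccc2)OS(=O)(=O)C=C1OCc1ccc(OC)cc1`: >= 200000 nM

Each of these three readings is a limit of the assay rather than a measured number. For compound 1 the limit is >= 20000 nM. For compound 2 the limit is > 400000 nM. For compound 3 the limit is >= 200000 nM, so compound 3 stands only at a limit, and the two other values shown are limits as well (the limit of > 400000 nM in this assay, at which 1 of the 3 values shown sits, (the limit of >= 20000 nM in this assay, at which 1 of the 3 values shown sits), (the limit of >= 200000 nM in this assay, at which 1 of the 3 values shown sits)).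

The three changes between the measured compounds, all on the saturated chain carbon bound to an oxygen on an unsaturated carbon, give no readable size: a step that the two limits leave unreadable from compound 1 to compound 2, a step that the two limits leave unreadable from compound 1 to compound 3 and a step that the two limits leave unreadable from compound 2 to compound 3.

Compound 4 `CCC1(Cc2ccccc2)OS(=O)(=O)C=C1OCc1ccc(Cl)cc1` differs from compound 3 by chloro in place of methoxy on an aromatic carbon. Among the measured compounds shown here, none of the measured steps touches this position, and none of them has a readable size, so no direction or size of change beyond the scatter can be expected on that basis in this assay. The most that can be said is that compound 3 sits at a limit and nothing argues for compound 4 leaving it.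

Compound 4 is therefore expected to give about 200000 nM in this assay, in a range from 50000 nM to 400000 nM. That estimate means a step of a number no higher from compound 3 to compound 4 (the limit leaves the size open), and the reading is expected to be a limit again rather than a number.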

Compound 4, minimum cytotoxic concentration: >= 50000 nM
Compound 4 gave a limit, no number; the forecaster's own chance of this, stated with the estimate: 85%; the middle value is on the limit's open side.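

Compound 4, like compound 1, compound 2 and compound 3, reads only as a limit in this assay, and no step among these four compounds can be read. The compounds shown leave open whether swapping methoxy for chloro, or changing the larger groups on the oxygen, shifts the minimum cytotoxic concentration at all, and by how much.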